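Swapping nitro for fluoro on an aryl lactone

A few compounds are considered here, and "the series" means these few. Any claim that something is new, unique, unknown or untested is made for them only; others in the source may bear on it.

Measured in a functional assay on A549 cells (Homo sapiens) for antiproliferative activity, read by luminescence and CellTiter-Glo, with a stated time of 48 h; on this read-out lower numbers stand for stronger inhibition and higher numbers for weaker inhibition:
Compound 1 `COc1ccc(/C=C/[C@H]2CC=CC(=O)O2)cc1`: > 100000 nM (a limit of the assay, not a number)
Compound 2 `O=C1C=CC[C@H](/C=C/c2ccc([N+](=O)[O-])cc2)O1`: 15400 nM

For the measured compounds named here, compound 2, at 15400 nM, holds the only true number in this assay so far. Compound 1 sits at the limit of > 100000 nM in this assay, at which 1 of the 2 values shown sits.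

Compound 3 `O=C1C=CC[C@H](/C=C/c2ccc(F)cc2)O1` has not yet been measured. It carries fluoro in place of nitro on an aromatic carbon.

Going by the values given here, only one measured step bears on this change. It is an at least 6.4-fold lower number from compound 1 to compound 2 (0.81 log units; beyond the scatter), with nitro in place of methoxy on an aromatic carbon, and it lies beyond the scatter. Fluoro itself is untested, and compound 3 loses the nitro that accompanied that gain. A step of a 2.6-fold higher number from compound 2 to compound 3 (0.41 log units; beyond the scatter) is therefore expected in this assay, towards weaker inhibition, though smaller than the measured one.

For compound 3 the estimated value is 40000 nM, with an expected range from 14000 nM to 100000 nM.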

Compound 3, half-maximal inhibitory concentration: 10200 nM
Compound 3: middle estimate off by 3.9-fold (0.59 log units), on the high side; measured number below the stated range.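

In this assay, fluoro in place of nitro gives a 1.5-fold lower number from compound 2 to compound 3 (0.18 log units; within the scatter), so at this place on the aromatic ring a group of 1 heavy atom with no hydrogen-bond acceptors cannot be told apart from one of 3 heavy atoms with 2 acceptors. Fluoro in place of methoxy gives an at least 9.8-fold lower number from compound 1 to compound 3 (0.99 log units; beyond the scatter), which shows that the shift first seen with nitro is not unique to nitro, and that methoxy is the group that stands apart among the three. The entry for compound 1 is a limit of the assay, not a number: the limit of > 100000 nM in this assay, at which 1 of the 3 values shown sits.

The compounds shown leave open whether a hydrogen, an amine or a trifluoromethyl group at this place would fall with fluoro and nitro or with methoxy. They also give no way of saying why methoxy stands apart.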